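The source may report more compounds than this note shows. Statements on the series, on what has been measured and on what is new or still open speak of the compounds shown alone.

Compound 1 `CCCCCCCCCCCCOC1=C(O)OC(C(O)CO)C1=O`: 54000 nM
Compound 2 `CCCCCCCCCCCCCOC1=C(O)OC(C(O)CO)C1=O`: 7400 nM
Compound 3 `CCCCCCCCCCCCCCCCCCCCOC1=C(O)OC(C(O)CO)C1=O`: 4700 nM

These three compounds share one core and differ only in the length of a straight saturated chain attached to it. In a functional assay (brain) for inhibition, with Rattus norvegicus as the target (a lower number here means a stronger inhibitor, a higher number a weaker inhibitor), compound 1 gives 54000 nM, compound 2 gives 7400 nM and compound 3 gives 4700 nM.

The change from compound 1 to compound 2 is methyl in place of hydrogen on a saturated chain carbon, ten or more bonds along the chain from an oxygen on an unsaturated carbon and it produced a 7.3-fold lower number from compound 1 to compound 2 (0.86 log units; beyond the scatter). Compound 3 differs from compound 1 by octyl in place of hydrogen on a saturated chain carbon, ten or more bonds along the chain from an oxygen on an unsaturated carbon, a step of an 11-fold lower number from compound 1 to compound 3 (1.06 log units; beyond the scatter). Yet the move from compound 2 to compound 3 gave only a 1.6-fold lower number from compound 2 to compound 3 (0.20 log units; within the scatter), so nearly all of the improvement arrived with the first added carbon, and seven further carbons changed little.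

Compound 4 `CCCCCCCCCCCCCCCCCCCCCOC1=C(O)OC(C(O)CO)C1=O` has not yet been measured in this assay. It differs from compound 3 by methyl in place of hydrogen on a saturated chain carbon, ten or more bonds along the chain from an oxygen on an unsaturated carbon, which is the same change as the one from compound 1 to compound 2; that change occurs twice among these compounds. The earlier instance gave a 7.3-fold lower number from compound 1 to compound 2 (0.86 log units; beyond the scatter), but the step from compound 3 to compound 4 is expected to be far smaller, roughly a 1.1-fold lower number from compound 3 to compound 4 (0.05 log units; within the scatter), because further lengthening of an already long chain gave only a 1.6-fold lower number from compound 2 to compound 3 (0.20 log units; within the scatter). Compound 4 is therefore estimated to give about 4200 nM in this assay, most likely between 2000 nM and 9000 nM.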

Compound 4, half-maximal inhibitory concentration: 11000 nM
Compound 4: middle estimate off by 2.6-fold (0.42 log units), on the low side, and the stated range ends below it.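

The new step is a 2.3-fold higher number from compound 3 to compound 4 (0.37 log units; beyond the scatter), so in this assay the same added methyl does not carry over from the shorter chain to the longer one, and even the direction of the step reverses: the same change on two cores in this assay, a 7.3-fold lower number (0.86 log units; beyond the scatter) from compound 1 to compound 2 and a 2.3-fold higher number (0.37 log units; beyond the scatter) from compound 3 to compound 4, 17-fold (1.23 log units) apart, beyond the scatter of two such steps The larger replacement of hydrogen by octyl does not carry over either, giving a 1.5-fold higher number from compound 2 to compound 4 (0.17 log units; within the scatter) when set against its earlier instance: the same change on two cores in this assay, an 11-fold lower number (1.06 log units; beyond the scatter) from compound 1 to compound 3 and a 1.5-fold higher number (0.17 log units; within the scatter) from compound 2 to compound 4, 17-fold (1.23 log units) apart, beyond the scatter of two such steps The longest chain here still gives a lower number than the shortest, with a 4.9-fold lower number from compound 1 to compound 4 (0.69 log units; beyond the scatter), but this shows only that the effect of added chain length depends on the chain it starts from, not why that is so, and four chain lengths cannot establish a best length or a general trend.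

The compounds shown leave open how chains of lengths falling in the gap from compound 2 to compound 3 behave, and whether a still longer chain would continue the rise in the number seen with compound 4. Also open, from the compounds shown here alone, is how a branched chain, or a chain carrying an amine or a carboxylic acid, would compare on the shared core.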